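A Terminal Amine Exchange on Compound 1

The source may report more compounds than this note shows. Statements on the series, on what has been measured and on what is new or still open speak of the compounds shown alone.

Compound 1: `COc1cc2c(Oc3ccc(NC(=O)c4cc(-c5ccccc5)ccn4)cc3F)ccnc2cc1OCCCN1CCN(C)CC1` — 1010 nM
Compound 2: `COc1ccc(-c2ccnc(C(=O)Nc3ccc(Oc4ccnc5cc(OCCCN6CCN(C)CC6)c(OC)cc45)c(F)c3)c2)c(OC)c1` — "not determined" (no result reported)

Going by the values given here, compound 1 is the only compound with a number in a functional assay on U-87MG ATCC cells (Homo sapiens) for cytotoxicity, read by MTT assay, with a stated time of 72 h; a lower number here means a stronger inhibitor, a higher number a weaker inhibitor; in this assay compound 1 gives 1010 nM, and compound 2 gives "not determined" (no result reported), so compound 1 stands alone, neither stronger nor weaker than any measured neighbour. Compound 3, `COc1cc2c(Oc3ccc(NC(=O)c4cc(-c5ccccc5)ccn4)cc3F)ccnc2cc1OCCCN1CCCC1`, is built from compound 1 by the change (pyrrolidin-1-yl in place of 4-methylpiperazin-1-yl on a saturated chain carbon, three bonds along the chain from an oxygen on an aromatic ring). Among the compounds with values here, no pair of measured compounds differs in one place, so there is no measured step to set a scale for this exchange, and the expectation for compound 3 rests on the value of compound 1 alone. With a ring amine kept at the end of the three-carbon chain, the step from compound 1 to compound 3 is expected to stay within the usual scatter, with at most a slight lean toward a stronger inhibitor, which is what a 1.3-fold lower number from compound 1 to compound 3 (0.10 log units; within the scatter) expresses. Compound 3 is therefore estimated at 800 nM in this assay, with a range from 300 nM to 2500 nM.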

Compound 3, half-maximal inhibitory concentration: 1010 nM
For compound 3 the middle estimate is 1.3-fold (0.10 log units) below the measured one, within the range that was stated.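

Going by these compounds alone, at the 3-carbon chain end, on a saturated chain carbon, three bonds along the chain from an oxygen on an aromatic ring, the earlier compounds offered no measured step, and in this assay the exchange now gives one: no change at the digits printed from compound 1 to compound 3 (within the scatter). On the core of compound 1, therefore, 4-methylpiperazin-1-yl is not required for this cytotoxicity reading, and the smaller pyrrolidin-1-yl, with one ring nitrogen and no methyl group, serves equally well, although this single pair cannot show how far that tolerance extends. No measurement at hand gives a reason for this result.

The compounds shown leave open whether the same holds for an open-chain amine such as dimethylamino, for a morpholin-4-yl ring, or for a terminal carboxylic acid in place of the ring amine. They also leave open whether a shorter 2-(pyrrolidin-1-yl)ethyl chain or a longer chain carrying the same ring would read alike, and whether the exchange would behave the same way on a core bearing a different group in place of the phenyl ring of compound 1.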